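A Methyl Group Moves on Compound 3

The source may report more compounds than this note shows. Statements on the series, on what has been measured and on what is new or still open speak of the compounds shown alone.

Three related compounds have been tested in a functional assay on SW480 cells (Homo sapiens) for antiproliferative activity, with a stated time of 72 h; on this read-out lower numbers stand for stronger inhibition and higher numbers for weaker inhibition. Compound 1 (`O=C(COc1ccc(CN2CC=C(c3c[nH]c4cccc(F)c34)CC2)cc1)NO`) gives 2310 nM, compound 2 (`O=C(COc1ccc(CN2CC=C(c3c[nH]c4ccc(F)cc34)CC2)c(F)c1)NO`) gives 3860 nM, and compound 3 (`Cc1ccc2[nH]cc(C3=CCC(NCc4ccc(OCC(=O)NO)cc4F)CC3)c2c1`) gives 2780 nM. Compound 3 thus stands within the scatter of both of the others, so its number cannot be set apart from either of theirs. No two of the three differ in one place alone, and the set therefore offers no direct measure of what a single change does.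

The next compound to be read is compound 4 (`Cc1[nH]c2ccccc2c1C1=CCC(NCc2ccc(OCC(=O)NO)cc2F)CC1`). It carries 2-methyl-1H-indol-3-yl in place of 5-methyl-1H-indol-3-yl on a double-bonded ring carbon of a six-membered non-aromatic ring of carbon only: 2-methyl-1H-indol-3-yl in place of 5-methyl-1H-indol-3-yl on a double-bonded ring carbon. The two have the same atoms, joined differently.

Among the compounds with values here, with no single-change step available, the expectation rests on the three values alone. Compound 1 at 2310 nM, compound 2 at 3860 nM and compound 3 at 2780 nM lie close together although their structures differ in more than one place. In this assay, no step beyond the scatter is expected, and no firm direction can be given. The estimated change is a 1.1-fold higher number from compound 3 to compound 4 (0.03 log units; within the scatter). For compound 4 the expected value is 3000 nM, with an estimated range from 1300 nM to 7000 nM.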

Compound 4, half-maximal inhibitory concentration: 170 nM
For compound 4 the middle estimate is 18-fold (1.25 log units) above the measured one; measured number outside the range, below it.
By their numbers in this assay, from the lowest: compound 4; then compounds 1, 3 and 2 (each within the scatter of the next).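

In this assay, within the data shown here, putting 2-methyl-1H-indol-3-yl in place of 5-methyl-1H-indol-3-yl on the double-bonded ring carbon gives a 16-fold lower number from compound 3 to compound 4 (1.21 log units; beyond the scatter) and is the first change in one place that this set can read. The two groups have the same atoms, the same ring counts and the same hydrogen-bond donor count, and they differ only in where the methyl group sits, so a move of one methyl group is enough here to take the number well beyond the scatter. The earlier compounds shown here could not show this, since no two of them differed in one place alone and their numbers all lay within the scatter of one another.

The compounds shown give no measurement that accounts for so large a step from a single moved methyl group. They also leave open whether the step belongs to the methyl group itself or to the place it now occupies, and whether an ethyl group or a chlorine atom standing in for the methyl of 2-methyl-1H-indol-3-yl would give a number like that of compound 4.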